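The source may report more compounds than this note shows. Statements on the series, on what has been measured and on what is new or still open speak of the compounds shown alone.

The measured compounds:
Compound 1, `COc1ncc(C(F)(F)F)cc1CO[C@H]1[C@H](C(C)(C)C)[C@@H](C(=O)O)N(C(=O)C2CCCCC2)[C@H]1c1ccccc1`, gives 150 nM in an assay on cells with Cystic fibrosis transmembrane conductance regulator variant F508del (Homo sapiens) as the target, read by voltage clamp, with a stated time of 24 h, in the presence of a further agent that is not named here; a higher number here means that more compound is needed for the effect, a lower number that less compound is needed.
Compound 2, `COc1ncc(C(C)(C)C)cc1CO[C@H]1[C@H](C(C)(C)C)[C@@H](C(=O)O)N(C(=O)C2CCCCC2)[C@H]1c1ccccc1`, gives 132 nM in this assay.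
Compound 3, `COc1ncc(C(F)(F)F)cc1CO[C@H]1[C@H](C(C)(C)C)[C@@H](C(=O)O)N(C(=O)[C@@H]2CCCCO2)[C@H]1c1ccccc1C1CC1`, gives 66 nM in this assay.

Compound 3 has the lowest of the three numbers. Its nearest neighbour is compound 2, whose number is higher only by an amount within the scatter, so these two cannot be placed in order; compound 1 lies further off, beyond the scatter. Compound 4, `COc1ncc(C(F)(F)F)cc1CO[C@H]1[C@H](C(C)(C)C)[C@@H](C(=O)O)N(C(=O)[C@@H]2CCCCO2)[C@H]1c1ccccc1CC(C)C`, differs from compound 3 in one place: isobutyl in place of cyclopropyl on an aromatic carbon. Going by the values given here, only one step between measured compounds is available, a 1.1-fold lower number from compound 1 to compound 2 (0.06 log units; within the scatter), and it concerns a different exchange, tert-butyl for trifluoromethyl, elsewhere in the molecule; it was within the scatter and gives no direct guide to replacing cyclopropyl with isobutyl. Among the compounds with values here, no measured pair here addresses that exchange, so compound 3's own number is the sole anchor, and compound 4 carries the rest of that structure unchanged. With nothing to point in either direction, the expected change in this assay from compound 3 to compound 4 is a 1.1-fold higher number from compound 3 to compound 4 (0.06 log units; within the scatter), that is, none beyond the scatter. Compound 4 is therefore estimated at 75 nM, with a range from 30 nM to 190 nM.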

Compound 4, half-maximal effective concentration: 52 nM
Compound 4: middle estimate off by 1.4-fold (0.16 log units), on the high side; measured number inside the range.
By their numbers in this assay, from the lowest: compounds 4, 3, 2 and 1 (each within the scatter of the next, the first and the last beyond it).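

In this assay, the exchange of cyclopropyl for isobutyl on an aromatic carbon, ortho to a large group, gives a 1.3-fold lower number from compound 3 to compound 4 (0.10 log units; within the scatter) and so does not separate the two compounds. Going by these compounds alone, this is the first information on this position, and it shows that the three-membered ring of cyclopropyl can give way to isobutyl, which has no ring and one more heavy atom, without a change beyond the scatter in this pair. No measurement offered here explains this result.

The compounds shown leave open what a longer chain, an amine or a carboxylic acid at this place would do to the number in this assay. They also leave open how much either group contributes compared with a bare hydrogen, since compound 1 and compound 2 carry no group at this place but also differ from compound 3 and compound 4 in the acyl group on the ring nitrogen, so no single-place comparison can be read.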